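Propyl in place of the arylidene group of compound 2

The source may report more compounds than this note shows. Statements on the series, on what has been measured and on what is new or still open speak of the compounds shown alone.

Among the measured compounds shown here, compound 2 `CC(=O)OC[C@H]1O[C@@H](n2cc(CN3C(=O)/C(=C\c4ccc(N(C)C)cc4)c4ccccc43)nn2)[C@H](OC(C)=O)[C@@H](OC(C)=O)[C@@H]1OC(C)=O` is the one member of the series with a numerical result: in an ADME assay on NIH3T3 cells (Homo sapiens) for cytotoxicity, read by sulforhodamine B assay, with a stated time of 48 h (a higher number here means a weaker inhibitor, a lower number a stronger inhibitor), compound 2 gives 17000 nM. Compound 1 `COc1ccc(/C=C2\C(=O)N(Cc3cn([C@@H]4O[C@H](COC(C)=O)[C@@H](OC(C)=O)[C@H](OC(C)=O)[C@H]4OC(C)=O)nn3)c3ccccc32)cc1OC` reaches only a limit of the assay. For compound 1 the reading in this assay is > 100000 nM. For the measured compounds named here, the single measured step, an at least 5.8-fold lower number from compound 1 to compound 2 (0.76 log units; beyond the scatter), rests on that limit on one side (the limit of > 100000 nM in this assay, at which 1 of the 2 values shown sits), so its true size is not fixed. Compound 3 `CCC/C=C1\C(=O)N(Cc2cn([C@@H]3O[C@H](COC(C)=O)[C@@H](OC(C)=O)[C@H](OC(C)=O)[C@H]3OC(C)=O)nn2)c2ccccc21` is not yet measured. It differs from compound 2 at one place: propyl in place of 4-(dimethylamino)phenyl on a double-bonded chain carbon bound to a double-bonded ring carbon. Going by the values given here, the measured step concerns the same position, but swaps one aryl group for another; the move to propyl removes the ring altogether, and no measured pair shows what that does. The swap of aryl groups from compound 1 to compound 2 moved the number by at least a modest amount, so this position is sensitive. The expectation for compound 3 is a higher number, that is weaker inhibition, with a fair chance that the result returns to a limit; the expected step is a 3.5-fold higher number from compound 2 to compound 3 (0.55 log units; beyond the scatter). Compound 3 is estimated at 60000 nM, within a range from 15000 nM to 250000 nM.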

Compound 3, half-maximal inhibitory concentration: > 100000 nM
Compound 3: no number, only a limit (the forecaster's own chance of this, stated with the estimate: 40%); middle value at least 1.6-fold (0.22 log units) from the limit.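

In this assay, losing the aromatic ring at this place, with propyl in place of 4-(dimethylamino)phenyl, gives an at least 5.8-fold higher number from compound 2 to compound 3 (0.76 log units; beyond the scatter), and that size is only a lower bound on the true step. Among the compounds shown here, compound 2 therefore remains the only compound with a number, and the position now proves sensitive to two different changes, since both a change of aryl substituents and the loss of the ring end at the same limit: the limit of > 100000 nM in this assay, at which 2 of the 3 values shown sit. The step between compound 1 and compound 3 cannot be read, so 3,4-dimethoxyphenyl and propyl cannot be ranked against each other.

The compounds shown do not tell whether the number in compound 2 depends on the dimethylamino group itself or on that group being carried on an aromatic ring, and how far compound 1 and compound 3 lie beyond the limit stays unknown. An unsubstituted phenyl would test the first question, and a propyl chain ending in a dimethylamino group would show whether that amine gives a number without the ring.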